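Adding Methoxy to Compound 2: What Size of Step?

The source may report more compounds than this note shows. Statements on the series, on what has been measured and on what is new or still open speak of the compounds shown alone.

Within the data shown here, in an ADME assay on HaCaT cells (Homo sapiens) for cytotoxicity, read by MTT assay, with a stated time of 48 h (a lower number here means a stronger inhibitor, a higher number a weaker inhibitor), compound 2 `FC(F)(F)c1ccc2[nH]c(-c3cn(-c4ccccc4)nc3-c3ccccc3)nc2c1` gives 37200 nM as the only actual number among the three compounds measured. For compound 1 `Brc1ccc2[nH]c(-c3cn(-c4ccccc4)nc3-c3ccccc3)nc2c1` the reading of > 50000 nM is a limit of the assay and not a number. For compound 3 `O=C(OCc1ccccc1)c1ccc2[nH]c(-c3cn(-c4ccccc4)nc3-c3ccccc3)nc2c1` the reading of > 50000 nM is likewise a limit. In compound 4 `COc1ccc(-c2nn(-c3ccccc3)cc2-c2nc3cc(C(F)(F)F)ccc3[nH]2)cc1` the change methoxy in place of hydrogen on an aromatic carbon puts methoxy in place of hydrogen on an aromatic carbon. The measured steps of an at least 1.3-fold lower number from compound 1 to compound 2 (0.12 log units; that floor lies within the scatter) and an at least 1.3-fold higher number from compound 2 to compound 3 (0.12 log units; that floor lies within the scatter) swap a different group, and neither involves methoxy, so they offer only weak guidance. A step of a 1.0-fold higher number from compound 2 to compound 4 (0.01 log units; within the scatter) is therefore expected, with nothing beyond the scatter. Compound 4 is estimated at 38000 nM with a range from 18000 nM to 70000 nM as the expected reading in this assay here.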

Compound 4, half-maximal inhibitory concentration: > 50000 nM
Compound 4: only a limit was reported; the forecaster's own chance of this, stated with the estimate: 35%; middle value at least 1.3-fold (0.11 log units) away from the limit.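

Among these compounds, the change from phenyl to 4-methoxyphenyl gives the first step at this position, para to a large group, and it is an at least 1.3-fold higher number from compound 2 to compound 4 (0.12 log units; that floor lies within the scatter). In this assay compound 4 reads > 50000 nM, which is a limit and not a number. The step therefore has only a floor, and its full size cannot be read because the readings stop at that limit: the limit of > 50000 nM in this assay, at which 3 of the 4 values shown sit.

On these data alone, whether an amine or a carboxylic acid at this same place would give a lower number than compound 2 stays open. So does what methoxy would do elsewhere on this ring.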